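The source may report more compounds than this note shows. Statements on the series, on what has been measured and on what is new or still open speak of the compounds shown alone.

In a functional assay on HL-60 cells (Homo sapiens) for cytotoxicity, read by XTT assay, with a stated time of 72 h (a higher number here means a weaker inhibitor, a lower number a stronger inhibitor), compound 1 (`CCCCCCCC/C=C\CCCCCCCCOc1cc(O)c(C(C)=O)c(O)c1`) gives 32000 nM and stands level with compound 2 (`CCCCCCCC/C=C\CCCCCCCCOc1cc(O)cc(O)c1C(C)=O`) at 32000 nM in the series. Compound 3 (`CC(=O)c1c(O)cc(O)cc1OC/C=C(\C)CC/C=C(\C)CCC=C(C)C`) gives 31000 nM and sits within the scatter of both. Compound 4 (`CCCCCCCCCCCCCCCCCCOc1cc(O)c(C(C)=O)c(O)c1`) is still unmeasured. It differs from compound 1 (decyl in place of dec-1-en-1-yl on a saturated chain carbon, eight bonds along the chain from an oxygen on an aromatic ring) with decyl in place of dec-1-en-1-yl on a saturated chain carbon, eight bonds along the chain from an oxygen on an aromatic ring. Within the data shown here, no measured pair shows this change alone. Since compound 3 with its different chain gives 31000 nM as well, no step beyond the scatter is expected in this assay for this change. The estimated step is no change at the digits printed from compound 1 to compound 4 (within the scatter) and nothing larger is expected. For compound 4 the expected value is 32000 nM (estimated range 14000 nM to 70000 nM).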

Compound 4, half-maximal inhibitory concentration: > 100000 nM
Compound 4 ended at the assay's limit (the forecaster's own chance of this, stated with the estimate: 25%); middle value at least 3.1-fold (0.49 log units) from the limit.
By their numbers in this assay, from the lowest: compounds 3, 1 and 2 (each within the scatter of the next). At a limit, above all of these: compound 4.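

In this assay, the chain of compound 1 proves sensitive to saturation: decyl in place of dec-1-en-1-yl, eight bonds along the chain from an oxygen on an aromatic ring, gives an at least 3.1-fold higher number from compound 1 to compound 4 (0.49 log units; beyond the scatter). Compound 4 gives > 100000 nM, which is a limit of the assay and not a number. Only a lower bound on the step is therefore fixed: the limit of > 100000 nM in this assay, at which 1 of the 4 values shown sits.

Open, going by these compounds, is whether a trans double bond at this place would match compound 1. Also open, on these data alone, is how a shorter chain, or a terminal amine or carboxylic acid, would read.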